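Three cinnamate esters at a single dose, and a fourth to come

A few compounds are considered here, and "the series" means these few. Any claim that something is new, unique, unknown or untested is made for them only; others in the source may bear on it.

Compound 1 `COc1cc(OC)c(OC)cc1/C=C/COC(=O)/C=C/c1cc(OC)c(OC)c(OC)c1OC` gives 100% in a functional assay on the whole organism (strain Kunming) with Mus musculus as the target, with a stated time of 0.5 h, at a dose of 300 mg/kg by the intraperitoneal route; on this read-out lower numbers stand for a stronger effect and higher numbers for a weaker effect at the one dose given.
Compound 2 `COc1cc(OC)c(OC)cc1/C=C/COC(=O)/C=C/c1ccccc1C(F)(F)F` gives 100% in this assay.
Compound 3 `COc1cc(OC)c(OC)cc1/C=C/COC(=O)/C=C/c1ccc(OC)c(OC)c1OC` gives 100% in this assay.

All three measured esters share the same trimethoxy-substituted allylic alcohol part and differ only in the aryl group on the cinnamate side. Among the compounds with values here, the one measured step between neighbours, no change at the digits printed from compound 1 to compound 3 (within the scatter), shows no shift beyond the scatter. Compound 2 sits level with compounds 1 and 3 at the digits shown; its nearest neighbour by value is compound 1, and even its furthest, compound 3, lies within the scatter.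

Compound 4 `COc1ccc(/C=C/C(=O)OC/C=C/c2cc(OC)c(OC)cc2OC)cc1` has not yet been measured. It differs from compound 2 as follows: 4-methoxyphenyl in place of 2-(trifluoromethyl)phenyl on a double-bonded chain carbon bound to a double-bonded chain carbon. Within the data shown here, no measured step addresses this particular swap, and the one step that does exist on the cinnamate aryl, from compound 1 to compound 3, was flat. On that basis the step of no change at the digits printed from compound 2 to compound 4 (within the scatter) is expected to be no larger than the scatter. Compound 4 is therefore estimated to give 100% in this assay, within 85% to 100%.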

Compound 4, a percentage reported as activity, at one dose (the size of the read-out at that dose, not a potency): 100%
The estimate for compound 4 equals the measured number at the digits printed; low and high end bracket the measured number.
By their numbers in this assay, from the lowest: compounds 1, 2, 3 and 4 (each within the scatter of the next).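

The step of no change at the digits printed from compound 2 to compound 4 (within the scatter) in this assay extends the flat picture on the cinnamate side to a swap of a different kind. The earlier step only took away a methoxy group from an aryl group that kept its other methoxy groups, whereas here 4-methoxyphenyl, which carries oxygen, replaces 2-(trifluoromethyl)phenyl, which carries fluorine, and the read-out still does not separate the two compounds. The data offer no explanation for this flatness.

Going by these compounds, whether an amine or a carboxylic acid on the aryl group at this place, or a longer chain in place of that group, would move the read-out remains open. So does whether any change to the shared trimethoxy-substituted allylic alcohol part would do so.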